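Swapping the Aryl Group on the Ring Nitrogen

The compounds below may be only part of what the source reports. "The series", "measured", "known", "first", "only" and "open" are said of these compounds alone.

Compound 1 `COc1ccc(-n2nc(-c3ccc(C(F)(F)F)cc3O)nc2-c2ccccc2O)cc1` in a functional assay on PC-12 cells (Rattus norvegicus) for cytotoxicity, read by MTT assay, with stated times of 2 h and 24 h, tested at 10 uM (a lower number here means a weaker effect, a higher number a stronger effect of the compound at the concentration tested), gives 98.9%.
Compound 2 `N#Cc1ccc(-n2nc(-c3ccc(C(F)(F)F)cc3O)nc2-c2ccccc2O)cc1` in this assay gives 98.9%.

Within the data shown here, compound 1 stands level with compound 2 on these numbers: the single measured step, no change at the digits printed from compound 1 to compound 2 (within the scatter), lies within the scatter. Compound 3 `Oc1cc(C(F)(F)F)ccc1-c1nc(-c2ccccc2O)n(-c2cc(F)cc(F)c2)n1` differs from compound 1 by 3,5-difluorophenyl in place of 4-methoxyphenyl on an aromatic nitrogen. Among the measured compounds shown here, only the step from compound 1 to compound 2 bears on this change, and it bears loosely, as it exchanged cyano for methoxy on an aromatic carbon rather than replacing the whole 4-methoxyphenyl. Both measured values sit near the top of the read-out, so no step beyond the scatter is expected; the expected step is a number 1.9 percentage points lower from compound 1 to compound 3 (within the scatter). Compound 3 is estimated at 97%, with a range from 85% to 100%.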

Compound 3, a percentage reported as activity, at one concentration (the size of the read-out at that concentration, not a potency): 106%
For compound 3 the middle estimate is 9 percentage points below the measured one; measured number outside the range, above it.
By their numbers in this assay, from the lowest: compounds 1, 2 and 3 (each within the scatter of the next).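

Replacing the whole aryl group on the aromatic nitrogen, rather than one substituent on it, gives a step in this assay of a number 7.1 percentage points higher from compound 1 to compound 3 (within the scatter), and likewise a number 7.1 percentage points higher from compound 2 to compound 3 (within the scatter). At this position, then, 3,5-difluorophenyl cannot be told apart from 4-methoxyphenyl or 4-cyanophenyl, although it brings two fluorines and no hydrogen-bond acceptor. No measurement is available that would explain this result.

On these data alone, whether a carboxylic acid or an amine on this aryl group would give a value outside the scatter remains open. So does the effect of replacing the aryl group with a simple alkyl chain.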